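Purine ribosides as equilibrative nucleoside transporter 1 inhibitors

The compounds below may be only part of what the source reports. "The series", "measured", "known", "first", "only" and "open" are said of these compounds alone.

Measured so far:
compound 1 `O=[N+]([O-])c1ccc2c(c1)CN(c1ncnc3c1nc1n3[C@@H]3O[C@H](CO1)[C@@H](O)[C@H]3O)CC2`: 331 nM
compound 2 `OC[C@H]1O[C@@H](n2cnc3c(NCc4ccco4)ncnc32)[C@H](O)[C@@H]1O`: 36300 nM

In an assay on isolated protein for binding affinity to Equilibrative nucleoside transporter 1 (Homo sapiens) (a lower number here means a stronger inhibitor, a higher number a weaker inhibitor), compound 2 gives the highest of the two numbers; compound 1 gives a number far lower, beyond the scatter. Compound 3 `Cc1cccc(CSc2ncnc3c2ncn3[C@@H]2O[C@H](CO)[C@@H](O)[C@H]2O)c1` is not yet measured. It differs from compound 2 in one place: (3-methylbenzyl)sulfanyl in place of ((furan-2-yl)methyl)amino on an aromatic carbon. Going by the values given here, no step between measured compounds is available for this change. A step toward a lower number, beyond the scatter, is expected, a 73-fold lower number from compound 2 to compound 3 (1.86 log units; beyond the scatter), since compound 1 shows that a larger group in this region can give 331 nM. Compound 3 is estimated at 500 nM, with a range from 50 nM to 5000 nM.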

Compound 3, half-maximal inhibitory concentration: 12000 nM
The estimate for compound 3 lay 24-fold (1.38 log units) below the measured number; the measured number lies above the stated range.
By their numbers in this assay, from the lowest: compound 1; then compound 3; then compound 2.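

In this assay, (3-methylbenzyl)sulfanyl in place of ((furan-2-yl)methyl)amino on this aromatic carbon gives a 3.0-fold lower number from compound 2 to compound 3 (0.48 log units; beyond the scatter) as a modest step. The entering group has no hydrogen-bond donor, so compound 3 shows that a donor in this substituent is not needed for that lower number. The change alters the linking atom and the ring together, and no measured data bear on the cause of the step.

Which of the two alterations carries the step remains open. A benzylamino group or an unmethylated benzylsulfanyl group would separate them.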